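The source may report more compounds than this note shows. Statements on the series, on what has been measured and on what is new or still open speak of the compounds shown alone.

Of the compounds shown here, two sharing one core have been measured in a functional assay on SW-620 cells (Homo sapiens) for inhibition, read by MTT assay, with a stated time of 72 h; on this read-out higher numbers stand for weaker inhibition and lower numbers for stronger inhibition. Compound 1 `O=c1cc(Cn2cc(CCCCl)nn2)c2ccc(O)cc2o1` carries a chloromethyl at the end of its chain, and in this assay compound 1 gives 59800 nM. Compound 2 `O=c1cc(Cn2cc(CCc3ccccc3)nn2)c2ccc(O)cc2o1` carries a phenyl in that place instead, and in this assay compound 2 gives 84400 nM. For the measured compounds named here, the single step between them, a 1.4-fold higher number from compound 1 to compound 2 (0.15 log units; within the scatter), is small, so the two numbers lie within the scatter of each other and neither compound can be called the stronger or the weaker.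

Compound 3 `O=c1cc(Cn2cc(CSC(=S)N3CCNCC3)nn2)c2ccc(O)cc2o1` has not been measured. It differs from compound 2 by a group of 9 heavy atoms (5 carbon, 2 nitrogen, 2 sulfur; one six-membered non-aromatic ring with 2 hetero atoms) in place of a group of 7 heavy atoms (7 carbon; one six-membered aromatic ring of carbon only), on a saturated chain carbon bound to an aromatic carbon. Going by the values given here, the only measured step that touches this part of the molecule is a 1.4-fold higher number from compound 1 to compound 2 (0.15 log units; within the scatter), which changed nothing beyond the scatter, and no measured compound carries a group resembling the one that enters. With so little to go on, the expectation for compound 3 is a number close to that of compound 2, and the expected step of a 1.4-fold lower number from compound 2 to compound 3 (0.15 log units; within the scatter) is within the scatter. The estimate for compound 3 in this assay is therefore 60000 nM, with a range from 20000 nM to 200000 nM.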

Compound 3, half-maximal inhibitory concentration: > 100000 nM
Compound 3: a limit, no number (the forecaster's own chance of this, stated with the estimate: 20%); middle value at least 1.6-fold (0.22 log units) away from the limit.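

In this assay compound 3 gives > 100000 nM, which is a limit of the assay and not a number. The step of an at least 1.1-fold higher number from compound 2 to compound 3 (0.07 log units; that floor lies within the scatter) and the step of an at least 1.6-fold higher number from compound 1 to compound 3 (0.22 log units; that floor lies within the scatter) are therefore floors only: both lie within the scatter, so compound 3 cannot be called weaker than either earlier compound, although its true number could lie much further up. What is new is that a very different group, with a six-membered non-aromatic ring, nitrogen, sulfur and a hydrogen-bond donor, on a saturated chain carbon bound to an aromatic carbon, still brings no sign of stronger inhibition, and the reading now reaches the end of what the assay reports: the limit of > 100000 nM in this assay, at which 1 of the 3 values shown sits.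

The compounds shown do not reveal whether any group at this place can bring the number clearly down, for instance a simple amine, a carboxylic acid or a longer carbon chain. They also cannot separate the part played by the sulfur-bearing portion of the new group from that of its ring, since the two enter together.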